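A few compounds are considered here, and "the series" means these few. Any claim that something is new, unique, unknown or untested is made for them only; others in the source may bear on it.

Compound 1, `O=C(O)c1cc(-c2cncs2)ccc1O`: in a functional assay on the whole organism for inhibition, with Rattus norvegicus as the target, read by paw edema (a higher number here means that more compound is needed for the effect, a lower number that less compound is needed), compound 1 reaches only a limit, > 200 mg/kg.
Compound 2, `O=C(O)c1cc(-c2cc[nH]n2)ccc1O`: in this assay compound 2 likewise reaches only a limit, > 250 mg/kg.

Compound 2 stands at one of the two limits shown, where the limit of > 250 mg/kg in this assay, at which 1 of the 2 values shown sits, sits, and the step that the two limits leave unreadable from compound 1 to compound 2 cannot be read. Compound 3, `O=C(O)c1cc(-c2ncco2)ccc1O`, differs from compound 2 by 1,3-oxazol-2-yl in place of 1H-pyrazol-3-yl on an aromatic carbon. Going by the values given here, the one measured step bearing on this change is unreadable, so no direction beyond the scatter can be read for compound 3 in this assay. Compound 3 is therefore estimated at 300 mg/kg, between 120 mg/kg and 1000 mg/kg. The step that the limit leaves unreadable from compound 2 to compound 3 is thus expected to be small.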

Compound 3, dose for half-maximal effect: 100 mg/kg
Estimate against measurement, compound 3: 3.0-fold (0.48 log units) above, outside the stated range (below it).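

Going by these compounds alone, at this position, para to a hydroxy group, 1,3-oxazol-2-yl gives the first value in this assay that is not a limit, and the change from 1H-pyrazol-3-yl gives an at least 2.5-fold lower number from compound 2 to compound 3 (0.39 log units; beyond the scatter). The change from 1,3-thiazol-5-yl gives an at least 2.0-fold lower number from compound 1 to compound 3 (0.30 log units; that floor lies within the scatter). The size of the first step is only a floor because compound 2 stands at a limit: the limit of > 250 mg/kg in this assay, at which 1 of the 3 values shown sits.

From the compounds shown here alone, how far compound 1 and compound 2 truly lie from compound 3 stays open. Also open, going by these compounds, is whether an amine on the 1,3-oxazol-2-yl ring would move the number further.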